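The source may hold more compounds than are shown below. What is called first, only, known or untested is meant among the compounds shown, and "the series" means these compounds.

Two compounds have been examined in an ADME assay on BHK cells (Mesocricetus auratus) for cytotoxicity, read by MTT assay, with a stated time of 96 h; on this read-out higher numbers stand for lower toxicity in this test and lower numbers for higher toxicity in this test. Compound 1 `CC(=O)Nc1ccc(-c2nc3cc(C(F)(F)F)ccc3[nH]2)cc1` gives 53000 nM, and compound 2 `O=C(CN1CCCCC1)Nc1ccc(-c2nc3ccccc3[nH]2)cc1` gives 31000 nM. Compound 2 thus sits at the lower end of these two numbers, yet its gap to compound 1 lies within the usual scatter of such measurements, so no real difference between them can be claimed. Compound 3 `O=C(CN1CCCCC1)Nc1ccc(-c2nc3cc(C(F)(F)F)ccc3[nH]2)cc1` is yet to be measured. Its change from compound 2 is trifluoromethyl in place of hydrogen on an aromatic carbon. Since compound 1 carries the same trifluoromethyl and gives 53000 nM, the step in this assay from compound 2 to compound 3 is expected to stay within the scatter, a 1.3-fold higher number from compound 2 to compound 3 (0.11 log units; within the scatter). Compound 3 is therefore estimated at 40000 nM, between 15000 nM and 100000 nM.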

Compound 3, half-maximal cytotoxic concentration: 12000 nM
Beside the measured number, compound 3's estimate is 3.3-fold (0.52 log units) above it; measured number below the stated range.
By their numbers in this assay, from the lowest: compound 3; then compounds 2 and 1 (each within the scatter of the next).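

In this assay, trifluoromethyl on the aromatic carbon now shows an effect beyond the scatter, with a 2.6-fold lower number from compound 2 to compound 3 (0.41 log units; beyond the scatter) in a compound carrying piperidin-1-yl. On the chain side, piperidin-1-yl in place of hydrogen gives a 4.4-fold lower number from compound 1 to compound 3 (0.65 log units; beyond the scatter) in a compound carrying trifluoromethyl, so compound 3, holding both groups, is the most toxic of the three in this test. Nothing available explains these steps. From the compounds shown here alone, it remains open whether chlorine or a nitrile at this aromatic carbon would give a similar step. Going by these compounds, whether morpholine in place of piperidin-1-yl would do the same is also open.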